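The compounds below may be only part of what the source reports. "The series", "measured", "known", "first", "only" and "open" are said of these compounds alone.

Compounds measured so far:
- compound 1 `C#Cc1cccc(Nc2ncnc3cc(OC)c(OCCCCC(=O)Nc4ccc(S(N)(=O)=O)cc4)cc23)c1` — 18800 nM
- compound 2 `COc1cc2ncnc(Nc3cccc(Cl)c3)c2cc1OCCCCC(=O)Nc1ccc(S(N)(=O)=O)cc1` — 33200 nM

Both numbers come from a functional assay on NCI-H1975 cells (Homo sapiens) for antiproliferative activity, read by MTT assay, with a stated time of 72 h; a lower number here means a stronger inhibitor, a higher number a weaker inhibitor. Among the compounds with values here, compound 2 gives the higher of the two numbers; the only neighbour, compound 1, differs by a 1.8-fold higher number from compound 1 to compound 2 (0.25 log units; within the scatter), so the two compounds cannot be told apart on these data.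

The next compound, compound 3 `COc1cc2ncnc(Nc3ccc(F)cc3)c2cc1OCCCCC(=O)Nc1ccc(S(N)(=O)=O)cc1`, differs from compound 2 in one place: 4-fluorophenyl in place of 3-chlorophenyl on a nitrogen on an aromatic ring. The rest of the shared core and the side chain stay the same.

Within the data shown here, only one measured step touches the same part of the molecule, the change of the group on that nitrogen from compound 1 to compound 2, and it was within the scatter. Among the measured compounds shown here, no measured pair shows a 4-fluorophenyl at that position, so there is no direct basis for expecting a move in either direction. On what is known, compound 3 is expected to land near compound 2, with a step of a 1.2-fold higher number from compound 2 to compound 3 (0.08 log units; within the scatter) that stays within the scatter, and the estimate is 40000 nM (range 12000 nM to 130000 nM).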

Compound 3, half-maximal inhibitory concentration: > 40000 nM
Compound 3: no number, only a limit (the forecaster's own chance of this, stated with the estimate: 25%); the middle value sits exactly at the limit.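

In this assay compound 3 gives > 40000 nM, which is a limit of the assay and not a number. Within the data shown here, at the nitrogen on the aromatic ring, 4-fluorophenyl in place of 3-ethynylphenyl gives the first step in this small set that lies beyond the scatter, an at least 2.1-fold higher number from compound 1 to compound 3 (0.32 log units; beyond the scatter), so the group on this nitrogen can shift the reading, although the true size of that shift is hidden by the limit. The change from 3-chlorophenyl to 4-fluorophenyl gives only a floor, an at least 1.2-fold higher number from compound 2 to compound 3 (0.08 log units; that floor lies within the scatter), and that floor alone does not separate the two compounds, although the real step could be larger.

A 3-fluorophenyl on the same nitrogen would help show whether the step follows the change of group on the ring or the change in where that group sits, since the name changes in both respects here. Also open, on these data alone, is how a phenyl with no further group on this nitrogen, or a carboxylic acid or a longer chain in the side chain, would read in this assay.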